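Phenyl ketone expected close to its hydroxy parent

A few compounds are considered here, and "the series" means these few. Any claim that something is new, unique, unknown or untested is made for them only; others in the source may bear on it.

compound 1 `O=C(/C=C/c1cccc(OCc2ccccc2)c1)c1ccc([N+](=O)[O-])cc1` gives 17500 nM
compound 2 `O=C(/C=C/c1cccc(OCc2ccccc2)c1)c1ccc(O)cc1` gives 2800 nM
compound 3 `O=C(/C=C/c1cccc(OCc2ccccc2)c1)c1ccc(Cl)c(Cl)c1Cl` gives 2400 nM

All three values come from a functional assay on MCF7 cells (Homo sapiens) for cytotoxicity, read by MTT assay, with a stated time of 68 h; on this read-out higher numbers stand for weaker inhibition and lower numbers for stronger inhibition. Compound 2 belongs to the lower pair of the three numbers, and the gap within that pair is a 1.2-fold lower number from compound 2 to compound 3 (0.07 log units; within the scatter). Two modest steps lead down from the highest number: a 6.3-fold lower number from compound 1 to compound 2 (0.80 log units; beyond the scatter), and a 7.3-fold lower number from compound 1 to compound 3 (0.86 log units; beyond the scatter).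

The next structure is compound 4 `O=C(/C=C/c1cccc(OCc2ccccc2)c1)c1ccccc1`. The change is hydrogen in place of hydroxy on an aromatic carbon, para to a large group. Among the compounds with values here, no measured step removes a substituent outright, so the evidence is indirect. The only measured replacement of the 4-hydroxyphenyl group that stays clear of the nitro compound is a 1.2-fold lower number from compound 2 to compound 3 (0.07 log units; within the scatter), and the two modest steps both involve the 4-nitrophenyl group, which is not part of this change. The expected change is therefore small, namely a 1.4-fold higher number from compound 2 to compound 4 (0.15 log units; within the scatter), with no step beyond the scatter anticipated. For compound 4 the estimated value is 4000 nM, with an expected range of 1500 nM to 11000 nM.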

Compound 4, half-maximal inhibitory concentration: 9800 nM
Estimate against measurement, compound 4: 2.5-fold (0.39 log units) below; the measured number falls inside the stated range.
By their numbers in this assay, from the lowest: compounds 3 and 2 (each within the scatter of the next); then compounds 4 and 1 (each within the scatter of the next).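

In this assay the hydroxy on this aromatic carbon, para to a large group, does count: going to the plain phenyl ketone gives a 3.5-fold higher number from compound 2 to compound 4 (0.54 log units; beyond the scatter) and the 2,3,4-trichlorophenyl group stands apart from phenyl in the same way, with a 4.1-fold higher number from compound 3 to compound 4 (0.61 log units; beyond the scatter) as its step. Nitro does not separate from hydrogen, with a 1.8-fold lower number from compound 1 to compound 4 (0.25 log units; within the scatter) as the step, so the earlier gaps from compound 1 now read as gains from hydroxy and from the chlorines over the unsubstituted ring, not as a penalty from nitro. No measurement at hand gives a reason for these differences.

Going by these compounds, whether a methoxy group or an amine in the same place would follow hydroxy or stay with hydrogen remains open. So does whether a single chlorine would be enough to match the 2,3,4-trichlorophenyl group.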